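Halogen exchange at the fused ring of the shared core

The source may hold more compounds than are shown below. What is called first, only, known or untested is meant among the compounds shown, and "the series" means these compounds.

Measured compounds in a functional assay on cells (Cancer cell lines, Homo sapiens) for cytotoxicity, read by sulforhodamine B assay, with a stated time of 48 h; on this read-out lower numbers stand for stronger inhibition of growth and higher numbers for weaker inhibition of growth:
compound 1 `CN(C)c1ccc(C2CC(c3ccccc3)=NN2C2=NC(=O)/C(=C3\C(=O)Nc4ccccc43)S2)cc1` — 35300 nM
compound 2 `CN(C)c1ccc(C2CC(c3ccccc3)=NN2C2=NC(=O)/C(=C3\C(=O)Nc4ccc(Br)cc43)S2)cc1` — 420 nM

Compound 2 holds the lowest of the two numbers recorded in this assay. Going by the values given here, its only neighbour is compound 1, which carries hydrogen where compound 2 carries bromo; the single measured step, an 84-fold lower number from compound 1 to compound 2 (1.92 log units; beyond the scatter), is the whole of what the series shows so far, and it is large.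

Compound 3 `CN(C)c1ccc(C2CC(c3ccccc3)=NN2C2=NC(=O)/C(=C3\C(=O)Nc4ccc(Cl)cc43)S2)cc1` has not yet been measured in this assay. It differs from compound 2 by chloro in place of bromo on an aromatic carbon. Among the compounds with values here, no measured pair compares two halogens at this position; the one measured step concerns the gain of a halogen over hydrogen, not a change from one halogen to another, so it offers only an indirect guide. With the halogen retained at the same carbon, the expectation is that most of the gain seen in the step from compound 1 to compound 2 is kept, and that the move to compound 3, a 1.7-fold higher number from compound 2 to compound 3 (0.22 log units; within the scatter), stays within or only slightly beyond the usual scatter. Compound 3 is therefore estimated at 700 nM, with a plausible range from 250 nM to 2500 nM.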

Compound 3, concentration for total growth inhibition: 410 nM
Estimate against measurement, compound 3: 1.7-fold (0.23 log units) above; the measured number falls inside the stated range.
By their numbers in this assay, from the lowest: compounds 3 and 2 (each within the scatter of the next); then compound 1.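

In this assay, chloro in place of bromo on this aromatic carbon gives a 1.0-fold lower number from compound 2 to compound 3 (0.01 log units; within the scatter) and so leaves the two halogens indistinguishable at this position, a comparison the earlier pair could not offer. The large gain over hydrogen is therefore not confined to bromo, as an 86-fold lower number from compound 1 to compound 3 (1.93 log units; beyond the scatter) stands as a large step alongside an 84-fold lower number from compound 1 to compound 2 (1.92 log units; beyond the scatter) and the position now shows the same outcome with two different halogens. Nothing available explains why either halogen differs so sharply from hydrogen here or why the two halogens match.

On these data alone, whether this gain belongs to halogens as such remains open: fluoro or iodo at the same carbon would test how far the halogen series holds, while methyl, methoxy, an amine or a carboxylic acid would show whether a non-halogen group can reproduce it. Also open is whether chloro or bromo on another aromatic carbon of the shared core would give a step of similar size, since the compounds shown vary only this one place.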